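This account rests on a few compounds, and the source may have more. Where it says the series, first, only, none or still open, it means among the compounds named here.

In an assay on cells for agonist activity at Bombesin receptor subtype-3 (Homo sapiens), read by HTRF and inositol phosphate accumulation, with a stated time of 1 h (on this read-out higher numbers stand for an effect only at larger amounts of compound and lower numbers for an effect already at smaller amounts), compound 1 `COC(=O)c1ccccc1-c1ccc(CCc2ncc(CC(C)(C)C)n2CC(=O)O)cc1` gives 968 nM, while compound 2 `COC(=O)c1c(F)cccc1-c1ccc(CCc2ncc(CC(C)(C)C)n2Cc2ccc(C(=O)O)cc2)cc1` gives 3 nM, the lowest of the two numbers and separated from compound 1 by a gap well beyond the scatter. Compound 3 `COC(=O)c1c(F)cccc1-c1ccc(CCc2ncc(CC(C)(C)C)n2CCOc2cccc(O)c2)cc1` differs from compound 2 in a single spot: (3-hydroxyphenoxy)methyl in place of 4-carboxyphenyl on a saturated chain carbon bound to an aromatic nitrogen. The carboxylic acid that compound 2 carries on that group is thus gone, and a phenol arrives in its place. A step to a higher number is expected from compound 2 to compound 3, a 10-fold higher number from compound 2 to compound 3 (1.00 log units; beyond the scatter), beyond the scatter. Compound 3 is estimated to give 30 nM in this assay, within a range of 5 nM to 200 nM.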

Compound 3, half-maximal effective concentration: 13 nM
For compound 3 the middle estimate is 2.3-fold (0.36 log units) above the measured one; low and high end bracket the measured number.
By their numbers in this assay, from the lowest: compound 2; then compound 3; then compound 1.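

Swapping 4-carboxyphenyl for (3-hydroxyphenoxy)methyl gives a 4.3-fold higher number from compound 2 to compound 3 (0.64 log units; beyond the scatter) in this assay, a modest but real loss. A carboxylic acid on this group is therefore not essential at this position, since compound 3 still gives 13 nM with a phenol instead. No measurement given here explains the size of this step.

As far as these compounds go, it remains open whether the phenol hydroxyl contributes at all, which a plain phenoxy group would test. It is also unknown how an amine on that ring or a longer chain would fare.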